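Removing one hydroxy group from a growth inhibitor

The source may report more compounds than this note shows. Statements on the series, on what has been measured and on what is new or still open speak of the compounds shown alone.

In a functional assay on UACC-62 cells (Homo sapiens) for inhibition (on this read-out lower numbers stand for stronger inhibition of growth and higher numbers for weaker inhibition of growth), compound 1 (`NS(=O)(=O)c1ccc(/C=C/c2ccc(O)c(O)c2)cc1`) gives 23300 nM. Compound 2 (`COc1cccc(/C=C/c2ccc(S(N)(=O)=O)cc2)c1`) gives 14000 nM, which lies within the scatter of compound 1, so these two share the high end of the three numbers. Compound 3 (`NS(=O)(=O)c1ccc(/C=C/c2ccc(O)cc2)cc1`) gives 3400 nM, clearly lower than compound 1.

Compound 4 (`NS(=O)(=O)c1ccc(/C=C/c2cccc(O)c2)cc1`) has not yet been measured. It comes from compound 1 by one small edit: hydrogen in place of hydroxy on an aromatic carbon. In words, a hydrogen replaces a hydroxy group on an aromatic carbon, leaving the other hydroxy group in place.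

Among the measured compounds shown here, only one measured step is of the same kind, namely a 6.9-fold lower number from compound 1 to compound 3 (0.84 log units; beyond the scatter). That step also swaps a hydroxy group for hydrogen, but it removes the other hydroxy group of compound 1, so it is a guide and not a copy. Compound 2 adds a note of caution, since its methoxy group stands where compound 4 keeps its hydroxy group and its number stays close to that of compound 1. A step in the same direction as the measured one is therefore expected in this assay, though perhaps a somewhat smaller one.

The expected step is a 3.3-fold lower number from compound 1 to compound 4 (0.52 log units; beyond the scatter). For compound 4 the estimated value is 7000 nM, with an expected range from 2500 nM to 20000 nM.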

Compound 4, concentration for 50% growth inhibition: 18600 nM
The estimate for compound 4 lay 2.7-fold (0.42 log units) below the measured number, and the stated range covers the measured number.
By their numbers in this assay, from the lowest: compound 3; then compounds 2, 4 and 1 (each within the scatter of the next).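

In this assay, replacing the hydroxy group that sits ortho to a hydroxy group and para to a large group with hydrogen gives a 1.3-fold lower number from compound 1 to compound 4 (0.10 log units; within the scatter), so the data show no loss or gain from removing the group at this position. The two hydroxy groups of compound 1 therefore do not count alike, since the same kind of edit at the other hydroxy group gave a 6.9-fold lower number from compound 1 to compound 3 (0.84 log units; beyond the scatter), a step beyond the scatter, and the outcome of this change depends on where it is made. The hydroxy group that compound 4 keeps can also be compared with a methoxy group at that place, and removing the methyl from the oxygen gives a 1.3-fold higher number from compound 2 to compound 4 (0.12 log units; within the scatter), so these two compounds cannot be told apart in this growth read-out.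

Nothing measured here explains why one hydroxy group matters to the number and the other does not. As far as these compounds go, it remains open whether an amine, a carboxylic acid or a methoxy group at the position para to a large group would also stay within the scatter of compound 1, or would move the number as clearly as the step to compound 3 did.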